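Methoxy for bromo on the benzyl ring of compound 2

A few compounds are considered here, and "the series" means these few. Any claim that something is new, unique, unknown or untested is made for them only; others in the source may bear on it.

Compound 1: `O=S(=O)(NCCCNCc1ccccc1Cl)c1cc(C(F)(F)F)cc(C(F)(F)F)c1`, 9300 nM
Compound 2: `O=S(=O)(NCCCNCc1ccc(Br)cc1)c1cc(C(F)(F)F)cc(C(F)(F)F)c1`, 2600 nM

Of the compounds shown here, two have been measured in a functional assay on A2780 cells (Homo sapiens) for inhibition, read by MTT assay, with a stated time of 72 h; a higher number here means a weaker inhibitor of growth, a lower number a stronger inhibitor of growth. Compound 1 gives 9300 nM, and compound 2 gives 2600 nM, the lowest of the two numbers; the step of a 3.6-fold lower number from compound 1 to compound 2 (0.55 log units; beyond the scatter) is beyond the scatter.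

Compound 3, `COc1ccc(CNCCCNS(=O)(=O)c2cc(C(F)(F)F)cc(C(F)(F)F)c2)cc1`, is not yet measured. It differs from compound 2 by methoxy in place of bromo on an aromatic carbon, so that 4-bromophenyl becomes 4-methoxyphenyl. No measured step changes bromo into methoxy at the same place; the only step shown, a 3.6-fold lower number from compound 1 to compound 2 (0.55 log units; beyond the scatter), moves a halogen from one position to another and also exchanges chloro for bromo, so it bears on this change only loosely. The data give no ground for expecting a step in this assay beyond the scatter in either direction; the step of a 1.3-fold higher number from compound 2 to compound 3 (0.13 log units; within the scatter) is therefore expected to be small. Compound 3 is estimated to give 3500 nM, within a range from 1200 nM to 10000 nM.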

Compound 3, concentration for 50% growth inhibition: 1700 nM
Compound 3: middle estimate off by 2.1-fold (0.31 log units), on the high side, within the range that was stated.
By their numbers in this assay, from the lowest: compounds 3 and 2 (each within the scatter of the next); then compound 1.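

In this assay the exchange of bromo for methoxy on an aromatic carbon para to a large group gives a 1.5-fold lower number from compound 2 to compound 3 (0.18 log units; within the scatter), so this place takes a single bromine or a carbon and oxygen carrying one hydrogen-bond acceptor with no difference that can be told from the scatter. Compound 1 now stands apart from two compounds rather than one: a 5.5-fold lower number from compound 1 to compound 3 (0.74 log units; beyond the scatter) joins a 3.6-fold lower number from compound 1 to compound 2 (0.55 log units; beyond the scatter), yet each of these steps changes both the group and its place on the ring, so neither separates the two changes. Nothing available gives a reason for these numbers.

The compounds shown leave open whether 4-chlorophenyl or 2-methoxyphenyl would tell the effect of the place from that of the group, and how the plain phenyl compares with 4-bromophenyl and 4-methoxyphenyl. They also leave open whether the same indifference would hold for a nitrile, a carboxylic acid or a dimethylamino group at this place, and what a longer chain would do to the numbers.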